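From Aminophenyl Amide to Hydroxamic Acid on a Shared Core

The compounds below may be only part of what the source reports. "The series", "measured", "known", "first", "only" and "open" are said of these compounds alone.

Within the data shown here, compound 1 `Nc1ccccc1NC(=O)c1ccc(-c2nnc(Cc3cccc4ccccc34)o2)cc1` gives 16100 nM in an assay on isolated protein for inhibition of protein deacetylase HDAC6 (Homo sapiens), read by fluorescence, with a stated time of 15 min (on this read-out lower numbers stand for stronger inhibition and higher numbers for weaker inhibition), the higher of the two numbers measured so far. Compound 2 `O=C(/C=C/c1ccc(-c2nnc(Cc3c[nH]c4ccccc34)o2)cc1)NO` gives 30 nM in this assay, a far lower number, well beyond the usual scatter. Compound 3 `O=C(NO)c1ccc(-c2nnc(Cc3cccc4ccccc34)o2)cc1` keeps the core of compound 1 but carries one change, (hydroxy in place of 2-aminophenyl on an amide-type nitrogen). Among the measured compounds shown here, no measured pair isolates this change, so because compound 2 reaches 30 nM the step of a 130-fold lower number from compound 1 to compound 3 (2.13 log units; beyond the scatter) is expected to be a large drop, beyond the scatter. Compound 3 is therefore estimated at 120 nM, within a range from 25 nM to 600 nM.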

Compound 3, half-maximal inhibitory concentration: 4100 nM
Beside the measured number, compound 3's estimate is 34-fold (1.53 log units) below it, and the stated range ends below it.
By their numbers in this assay, from the lowest: compound 2; then compound 3; then compound 1.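

Replacing 2-aminophenyl with hydroxy on the amide-type nitrogen, with the shared core held fixed, gives a step that is modest but beyond the scatter (a 3.9-fold lower number from compound 1 to compound 3 (0.59 log units; beyond the scatter)). Among these compounds, this is the first reading of this change alone, and it shows that compound 3 still sits at 4100 nM in this assay. Nothing available explains the size of this step.

As far as these compounds go, whether an amine or a methoxy group in place of hydroxy would lower the number further remains open. So does whether this change would have a similar effect on a different core.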